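The compounds below may be only part of what the source reports. "The series", "measured", "known", "first", "only" and "open" are said of these compounds alone.

Measured compounds:
- compound 1, `Cc1cc(-n2ccnc2)c(S(C)(=O)=O)cc1C(=O)N=C(N)N`: 23 nM
- compound 2, `CS(=O)(=O)c1cc(C(=O)N=C(N)N)ccc1-n1ccnc1`: 150 nM
- compound 3, `Cc1cc(C#N)c(S(C)(=O)=O)cc1C(=O)N=C(N)N`: 70 nM

All three were tested in a functional assay for inhibition of sodium/hydrogen exchanger (Oryctolagus cuniculus); on this read-out lower numbers stand for stronger inhibition and higher numbers for weaker inhibition. Compound 1 and compound 2 share a core, and the change from compound 2 to compound 1 is methyl in place of hydrogen on an aromatic carbon. This step gave a 6.5-fold lower number from compound 2 to compound 1 (0.81 log units; beyond the scatter). Compound 3 carries a different core; the difference between the core of compound 2 and the core of compound 3 is not broken down here. Against compound 1, compound 3 shows a 3.0-fold higher number from compound 1 to compound 3 (0.48 log units; beyond the scatter).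

Compound 4, `Cc1c(C(=O)N=C(N)N)cc(S(C)(=O)=O)c(C#N)c1C`, has not yet been tested. It differs from compound 3 by methyl in place of hydrogen on an aromatic carbon. Going by the values given here, this is the same kind of change as the one from compound 2 to compound 1, but the surroundings of the place differ: in compound 4 the entering methyl sits ortho to a cyano group and ortho to a methyl group, meta to a group of 6 heavy atoms and meta to a methylsulfonyl group, whereas in compound 1 it sits ortho to a group of 6 heavy atoms, meta to a 1H-imidazol-1-yl group and para to a methylsulfonyl group. Because the earlier step gave a 6.5-fold lower number from compound 2 to compound 1 (0.81 log units; beyond the scatter), some gain is expected, but with the differing surroundings a smaller step, a 2.0-fold lower number from compound 3 to compound 4 (0.30 log units; within the scatter), is estimated. Compound 4 is therefore expected at about 35 nM, most likely between 12 nM and 100 nM.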

Compound 4, half-maximal inhibitory concentration: 370 nM
Compound 4: the middle estimate sits 11-fold (1.02 log units) below what was measured; the whole stated range lies below it.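

In this assay, methyl in place of hydrogen on an aromatic carbon gave a 5.3-fold higher number from compound 3 to compound 4 (0.72 log units; beyond the scatter), so the same change that helped on one core hurt on the other: the same change on two cores in this assay, a 6.5-fold lower number (0.81 log units; beyond the scatter) from compound 2 to compound 1 and a 5.3-fold higher number (0.72 log units; beyond the scatter) from compound 3 to compound 4, 34-fold (1.54 log units) apart, beyond the scatter of two such steps. The result of this change therefore cannot simply be carried from one core to another in this series, and even its direction has to be checked on each new core. These two pairs do not show why the steps differ, since the entering methyl has different surroundings in each pair, ortho to a cyano group and ortho to a methyl group in compound 4, and two pairs cannot separate the effect of those surroundings from that of the rest of each core.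

From the compounds shown here alone, it remains open whether this reversal belongs to methyl alone or would also appear with a chlorine atom or a methoxy group entering at the same place on the core of compound 3. A third core, such as one with an amine in place of the cyano group, could show which of the two steps is more typical.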